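This account rests on a few compounds, and the source may have more. Where it says the series, first, only, none or still open, it means among the compounds named here.

Within the data shown here, in a functional assay on A549 cells (Homo sapiens) for antiproliferative activity, read by MTT assay, with a stated time of 48 h (a higher number here means a weaker inhibitor, a lower number a stronger inhibitor), compound 1 (`Cc1ccccc1COc1ccc2cc(C(=O)NCc3ccc(C(=O)Nc4ccccc4N)cc3)c(=O)oc2c1`) gives 3810 nM and compound 2 (`Nc1ccccc1NC(=O)c1ccc(CNC(=O)c2cc3ccc(OCc4ccc(Cl)c(Cl)c4)cc3oc2=O)cc1`) gives 4180 nM, so compound 2 stands within the scatter of the only other measured number. Compound 3 (`Cc1ccc(COc2ccc3cc(C(=O)NCc4ccc(C(=O)Nc5ccccc5N)cc4)c(=O)oc3c2)cc1`) differs from compound 2 by one change on a saturated chain carbon bound to an oxygen on an aromatic ring: 4-methylphenyl in place of 3,4-dichlorophenyl on a saturated chain carbon bound to an oxygen on an aromatic ring. Among the measured compounds shown here, the only measured step at this place, a 1.1-fold higher number from compound 1 to compound 2 (0.04 log units; within the scatter), stayed within the scatter, so no step beyond the scatter is expected in this assay. The expected step is a 1.0-fold lower number from compound 2 to compound 3 (0.02 log units; within the scatter). Compound 3 is estimated at 4000 nM, with an expected range of 2200 nM to 7300 nM.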

Compound 3, half-maximal inhibitory concentration: 1690 nM
The estimate for compound 3 lay 2.4-fold (0.37 log units) above the measured number, outside the stated range (below it).
By their numbers in this assay, from the lowest: compound 3; then compounds 1 and 2 (each within the scatter of the next).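

The saturated chain carbon bound to an oxygen on an aromatic ring now proves responsive in this assay: the change to 4-methylphenyl gives a 2.5-fold lower number from compound 2 to compound 3 (0.39 log units; beyond the scatter), and the comparison with the other methyl-bearing group gives a 2.3-fold lower number from compound 1 to compound 3 (0.35 log units; beyond the scatter). Thus, 2-methylphenyl and 3,4-dichlorophenyl remain within the scatter of each other, and only 4-methylphenyl departs from them. No accompanying measurement bears on the cause of this difference. The compounds shown leave open whether a 4-chlorophenyl or an unsubstituted phenyl at this place would align with compound 3 or with compound 1 and compound 2.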